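A few compounds are considered here, and "the series" means these few. Any claim that something is new, unique, unknown or untested is made for them only; others in the source may bear on it.

Measured compounds:
- Compound 1, `O=C(CSc1nnc(-c2ccncc2)o1)N/N=C/c1ccccc1`, gives 14600 nM in a functional assay on MCF7 cells (Homo sapiens) for cytotoxicity, read by MTT assay, with a stated time of 48 h; on this read-out lower numbers stand for stronger inhibition and higher numbers for weaker inhibition
- Compound 2, `COc1cccc(/C=N/NC(=O)CSc2nnc(-c3ccncc3)o2)c1`, gives 13800 nM
- Compound 3, `O=C(CSc1nnc(-c2ccncc2)o1)N/N=C/c1ccccc1F`, gives 21800 nM

Compound 2 carries the lowest of the three numbers, but the steps linking it to the others are small: a 1.1-fold lower number from compound 1 to compound 2 (0.02 log units; within the scatter) and a 1.6-fold higher number from compound 2 to compound 3 (0.20 log units; within the scatter), both within the scatter. Compound 4, `COc1cc(/C=N/NC(=O)CSc2nnc(-c3ccncc3)o2)ccc1O`, is not yet measured. It differs from compound 2 by hydroxy in place of hydrogen on an aromatic carbon. The measured steps that bear on this are the additions of single small groups on the same ring, a 1.1-fold lower number from compound 1 to compound 2 (0.02 log units; within the scatter) and a 1.5-fold higher number from compound 1 to compound 3 (0.17 log units; within the scatter), neither beyond the scatter. No step beyond the scatter is therefore expected in this assay, and the estimated step is a 1.0-fold lower number from compound 2 to compound 4 (0.01 log units; within the scatter). For compound 4 the expected value is 13500 nM, with a range from 6500 nM to 28000 nM.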

Compound 4, half-maximal inhibitory concentration: 3780 nM
Compound 4: the middle estimate sits 3.6-fold (0.55 log units) above what was measured; the whole stated range lies above it.
By their numbers in this assay, from the lowest: compound 4; then compounds 2, 1 and 3 (each within the scatter of the next).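

In this assay, hydroxy on the aromatic ring, ortho to a methoxy group and para to a large group, gives a 3.7-fold lower number from compound 2 to compound 4 (0.56 log units; beyond the scatter), the first single addition on this ring to step beyond the scatter. The complete 4-hydroxy-3-methoxyphenyl group also separates from the other two rings, with a 3.9-fold lower number from compound 1 to compound 4 (0.59 log units; beyond the scatter) and a 5.8-fold lower number from compound 3 to compound 4 (0.76 log units; beyond the scatter). No measurement at hand explains this stronger inhibition. Going by these compounds, it remains open whether hydroxy would give a similar step without the methoxy group, and whether an amine or a carboxylic acid in the same place would do so.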